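A few compounds are considered here, and "the series" means these few. Any claim that something is new, unique, unknown or untested is made for them only; others in the source may bear on it.

Measured so far in a functional assay on PC-3 cells (Homo sapiens) for antiproliferative activity, read by WST assay, with a stated time of 3 days (on this read-out higher numbers stand for weaker inhibition and lower numbers for stronger inhibition), are two compounds:
- compound 1 (`CCCCOc1c(-c2cc(OC)c(OC)c(OC)c2)oc2ccccc2c1=O`) gives 12800 nM in this test
- compound 2 (`CCCCCCOc1c(-c2cc(OC)c(OC)c(OC)c2)oc2ccccc2c1=O`) gives 29200 nM in this test

Compound 1 holds the lower of the two numbers, which makes it the stronger inhibitor of this pair. The gap between them is a 2.3-fold higher number from compound 1 to compound 2 (0.36 log units; beyond the scatter) and counts as modest.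

Compound 3 (`COc1cc(-c2oc3ccccc3c(=O)c2OC(C)C)cc(OC)c1OC`) has not been measured yet. It keeps the core of compound 1 and alters only the group on the oxygen. The difference is isopropyl in place of butyl on an oxygen on an aromatic ring and amounts to butoxy to isopropoxy.

Within the data shown here, only one measured step bears on this change, the extension of the butyl chain on that same oxygen, and it raised the number. Compound 3 instead carries a group with fewer carbons, though a branched one, and a single step from a straight chain cannot settle what branching does. A step beyond the scatter in this assay is therefore not expected, with only a slight lean towards a lower number. The expected step is a 1.3-fold lower number from compound 1 to compound 3 (0.11 log units; within the scatter) and remains a rough guess. For compound 3 the estimated value is 10000 nM with an expected range from 3500 nM to 28000 nM in this test.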

Compound 3, half-maximal inhibitory concentration: 21200 nM
Estimate against measurement, compound 3: 2.1-fold (0.33 log units) below; the measured number falls inside the stated range.
By their numbers in this assay, from the lowest: compounds 1, 3 and 2 (each within the scatter of the next, the first and the last beyond it).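

In this assay, replacing butyl with isopropyl on the oxygen gives a 1.7-fold higher number from compound 1 to compound 3 (0.22 log units; within the scatter), while replacing hexyl with isopropyl gives a 1.4-fold lower number from compound 2 to compound 3 (0.14 log units; within the scatter). The earlier pair showed only that two straight chains on this oxygen can differ by more than the scatter; the branched isopropyl group now sits within the scatter of both, so this test cannot tell it apart from either one. Nothing available explains this pattern in the numbers.

With a single branched group and two straight chains, the effect of branching remains tangled with the effect of chain length, and a straight propyl chain on the same oxygen would help to separate the two. As far as these compounds go, it also remains open how this position would respond to a group of a different kind, such as a chain ending in an amine or a carboxylic acid.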